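Replacing the fluorocyclohexyl acid with a two-ring acid

This account rests on a few compounds, and the source may have more. Where it says the series, first, only, none or still open, it means among the compounds named here.

Measured so far in an ADME assay on microsomes from liver (Homo sapiens) for metabolic stability, with a stated time of 10 min; on this read-out higher numbers stand for a more stable compound and lower numbers for a less stable compound:
compound 1 `CO[C@]1(C(=O)N2CC[C@](c3ccc(C(F)(C(F)(F)F)C(F)(F)F)cc3)(S(=O)(=O)c3ccc(F)cc3)C2)CC[C@H](C(=O)O)CC1` gives 82%
compound 2 `O=C(O)[C@H]1CC[C@](F)(C(=O)N2CC[C@](c3ccc(C(F)(C(F)(F)F)C(F)(F)F)cc3)(S(=O)(=O)c3ccc(F)cc3)C2)CC1` gives "not determined" (no result reported)

Compound 2 has no place on the numbers: in this assay compound 2 is reported as "not determined" (no result reported) and no single figure exists for it. The only measured reference is therefore compound 1 at 82% on the same read-out. The compound awaiting measurement is compound 3 `O=C(O)C12CCC(C(=O)N3CC[C@](c4ccc(C(F)(C(F)(F)F)C(F)(F)F)cc4)(S(=O)(=O)c4ccc(F)cc4)C3)(CC1)CC2` and it keeps the shared core of compound 2. The structural change is a group of 11 heavy atoms (9 carbon, 2 oxygen; 2 six-membered non-aromatic rings of carbon only) in place of a group of 10 heavy atoms (7 carbon, 2 oxygen, 1 fluorine; one six-membered non-aromatic ring of carbon only), on a carbonyl carbon and it takes place on a carbonyl carbon, where the 4-carboxy-1-fluorocyclohexyl group leaves and a group with 2 six-membered non-aromatic rings of carbon only enters. Among the compounds with values here, no measured step covers this kind of replacement, so the data give no direct size for it. With only compound 1 at 82% as a guide, a step beyond the scatter is not expected, and no direction is favoured, although the uncertainty is wide. In this assay compound 3 is estimated at 80% with a range from 60% to 96% expected.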

Compound 3, percent of the compound remaining: 100%
Compound 3: middle estimate off by 20 percentage points, on the low side; the whole stated range lies below it.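

Within the data shown here, the carbonyl carbon whose other neighbour is the amide-type nitrogen in a ring now has its first measured step, as the earlier compounds offered no pair that differed only there. In this assay, exchanging the group with one six-membered non-aromatic ring of carbon only in compound 1 for the group with 2 six-membered non-aromatic rings of carbon only gives a number 18 percentage points higher from compound 1 to compound 3 (beyond the scatter), so this position accepts the larger ring count without any loss on this read-out, and compound 3 reaches 100% on it. Nothing shown here accounts for the rise, which stands as an observation without a measured explanation.

The compounds shown leave open how the 4-carboxy-1-fluorocyclohexyl group of compound 2 compares directly with the new group, since compound 2 has no number on this read-out. They also leave open whether the result holds when the carboxylic acid on the new group gives way to a primary amide or a tetrazole, or when a single methoxy group or fluorine is added to its rings.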